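Changing the Group on the Ring Nitrogen of Compound 2

The source may report more compounds than this note shows. Statements on the series, on what has been measured and on what is new or still open speak of the compounds shown alone.

In a physicochemical assay for solubility, measured as kinetic solubility (a higher number here means a more soluble compound, a lower number a less soluble compound), compound 2 `O=C(Nc1ccc(Cl)c(C(F)(F)F)c1)N[C@H]1CCN(c2ccc3nncn3n2)C1` gives 1000 nM. Compound 3 `O=C(Nc1ccc(Cl)c(C(F)(F)F)c1)N[C@@H]1CCN(c2ccc3nncn3n2)C1` gives 1000 nM, and the two stand level. What separates them is the fact that compounds 2 and 3 differ only in the configuration as drawn, and the step between them is no change at the digits printed from compound 2 to compound 3 (within the scatter). Compound 1 `CNc1nccc(N2CC[C@H](NC(=O)Nc3ccc(OC)cc3)C2)n1` gives 92600 nM, which leaves compounds 2 and 3 sharing the lowest of the three numbers.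

Compound 4 `O=C(Nc1ccc(Cl)c(C(F)(F)F)c1)N[C@H]1CCN(c2ccnc(NC3CC3)n2)C1` keeps the rest of compound 2 and changes one group: a group of 10 heavy atoms (7 carbon, 3 nitrogen; one three-membered non-aromatic ring of carbon only, one six-membered aromatic ring with 2 hetero atoms) in place of a group of 9 heavy atoms (5 carbon, 4 nitrogen; one five-membered aromatic ring with 3 hetero atoms, one six-membered aromatic ring with 2 hetero atoms), on an amine nitrogen in a ring. The entering group is 2-(cyclopropylamino)pyrimidin-4-yl. Within the data shown here, no measured step makes this exchange. The step of no change at the digits printed from compound 2 to compound 3 (within the scatter) concerns configuration only, so it gives no size for a change of group. Compound 1, at 92600 nM, also has a six-membered aromatic ring with 2 hetero atoms on an amine nitrogen in a ring, but it differs from compound 4 elsewhere too. Its high value is therefore only a weak hint of upward movement, and compound 4 shares its remaining structure with compound 2, at 1000 nM.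

The expected step is small and upward, within the scatter: a 1.5-fold higher number from compound 2 to compound 4 (0.18 log units; within the scatter). For compound 4 the estimated value is 1500 nM, with an expected range from 400 nM to 8000 nM.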

Compound 4, solubility: 49200 nM
Beside the measured number, compound 4's estimate is 33-fold (1.52 log units) below it; measured number outside the range, above it.
By their numbers in this assay, from the lowest: compounds 2 and 3 (each within the scatter of the next); then compounds 4 and 1 (each within the scatter of the next).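

In this assay, the group on the amine nitrogen of the five-membered ring proves to be a place where the number can move a long way: putting 2-(cyclopropylamino)pyrimidin-4-yl there gives a 49-fold higher number from compound 2 to compound 4 (1.69 log units; beyond the scatter) on the same remaining structure. Among these compounds, the only earlier step between closely matched compounds concerned configuration at a saturated ring carbon and gave no change at the digits printed from compound 2 to compound 3 (within the scatter) so it set no size for a change of group, whereas this exchange shows that the group at this position can matter far more than the scatter. Several features change together in this one exchange, since the leaving group has a five-membered aromatic ring with 3 hetero atoms and 0 hydrogen-bond donors while the entering group has a three-membered carbon ring and 1 hydrogen-bond donor, and nothing measured here says which of these features accounts for the step.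

From the compounds shown here alone, it remains open how the number would read with a morpholine ring or a plain primary amine in place of the cyclopropylamino part of the entering group. Also open, going by these compounds, is whether a change of configuration would leave compound 4 as unmoved as it left compound 2.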